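The source may hold more compounds than are shown below. What is called first, only, known or untested is meant among the compounds shown, and "the series" means these compounds.

Compound 1 `Cc1nc(NC(C2CC2)C2CC2)c2nc(C)n(-c3ccc(C#N)cc3)c2n1`: 62 nM
Compound 2 `Cc1nc(NC(C2CC2)C2CC2)c2nc(C)n(-c3ccc(F)cc3)c2n1`: 91 nM
Compound 3 `CCOc1ccc(-n2c(C)nc3c(NC(C4CC4)C4CC4)nc(C)nc32)cc1`: 20 nM

Three compounds on a shared core were measured in a functional assay on CHO cells for antagonist activity at corticotropin-releasing factor receptor 1 (Homo sapiens), read by cAMP accumulation; a higher number here means a weaker inhibitor, a lower number a stronger inhibitor. Compound 3 gives the lowest number of the three: a 3.1-fold lower number from compound 1 to compound 3 (0.49 log units; beyond the scatter) and a 4.6-fold lower number from compound 2 to compound 3 (0.66 log units; beyond the scatter), both beyond the scatter, whereas a 1.5-fold higher number from compound 1 to compound 2 (0.17 log units; within the scatter). Compound 4 `Cc1nc(NC(C2CC2)C2CC2)c2nc(C)n(-c3ccc(OC(F)F)cc3)c2n1` differs from compound 3 by difluoromethyl in place of ethyl on an oxygen on an aromatic ring. For the measured compounds named here, none of the measured steps touches this oxygen-bound group; the three steps all exchange the whole substituent on the aromatic carbon. They show that the ethoxy compound 3 stands apart from the cyano compound 1 and the fluoro compound 2, but they give no direct reading on an ethyl-to-difluoromethyl exchange on the oxygen. The nearest guide is that every substituent other than ethoxy at this aromatic carbon gave a higher number, as seen in the steps from compound 1 and from compound 2 to compound 3. Compound 4 is therefore expected to give a number somewhat above that of compound 3, a 1.8-fold higher number from compound 3 to compound 4 (0.24 log units; within the scatter), though a result within the scatter of compound 3 would not be a surprise. The estimate for compound 4 in this assay is 35 nM, with a range from 12 nM to 100 nM.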

Compound 4, inhibition constant: 5 nM
Compound 4: middle estimate off by 7.0-fold (0.85 log units), on the high side; the measured number lies below the stated range.
By their numbers in this assay, from the lowest: compound 4; then compound 3; then compounds 1 and 2 (each within the scatter of the next).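

Compound 4 shows that the group on this oxygen matters in its own right: in this assay, difluoromethyl in place of ethyl gives a 4.0-fold lower number from compound 3 to compound 4 (0.60 log units; beyond the scatter), so the earlier edge of ethoxy over cyano and fluoro was not the limit at this aromatic carbon. Set against those two substituents, difluoromethoxy gives larger steps than ethoxy did, with an 18-fold lower number from compound 2 to compound 4 (1.26 log units; beyond the scatter) and a 12-fold lower number from compound 1 to compound 4 (1.09 log units; beyond the scatter), and since all three of its steps lie beyond the scatter, compound 4 is the strongest inhibitor of the four. The compounds shown offer a size for this gain but nothing that accounts for it.

On these data alone, it remains open whether the step comes from the fluorine atoms or from the loss of a carbon from the chain, a question that methoxy on the same oxygen would help to separate, while trifluoromethyl there would show whether a third fluorine goes with a lower or a higher number. Also open, as far as these compounds go, is how a longer chain on this oxygen, such as propyl, would compare with ethyl.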